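The source may hold more compounds than are shown below. What is called first, only, known or untested is meant among the compounds shown, and "the series" means these compounds.

In an assay on isolated protein for inhibition of protein kinase C theta type (Homo sapiens), read by TR-FRET, with a stated time of 2 h (a lower number here means a stronger inhibitor, a higher number a weaker inhibitor), compound 1 `N#Cc1cnc(NCc2cnccc2C(F)(F)F)cc1NC[C@H]1C[C@H](O)C1` gives 700 nM, the highest of the three numbers in hand. Compound 2 `CC(C)(C)Oc1ncncc1CNc1cc(N[C@H]2CC[C@@H](O)CC2)c(C#N)cn1` gives 200 nM and compound 3 `N#Cc1cnc(NCc2cncnc2OCC(F)F)cc1N[C@H]1CC[C@@H](O)CC1` gives 90 nM; both stand well below compound 1, and each differs from it in more than one place, so their values show only that they are the stronger inhibitors. Going by the values given here, the one single-point comparison, a 2.2-fold lower number from compound 2 to compound 3 (0.35 log units; beyond the scatter), concerns the group on an oxygen on an aromatic ring and not the amine substituent. Compound 4 `CC1(C)[C@@H](Nc2cc(NCc3cnccc3C(F)(F)F)ncc2C#N)C[C@@H]1C(N)=O` is not yet measured; it differs from compound 1 by 3-carbamoyl-2,2-dimethylcyclobutyl in place of (3-hydroxycyclobutyl)methyl on a nitrogen on an aromatic ring. Among the compounds with values here, no measured step touches this position, so nothing in hand sets the direction or size of the change; the comparison of compound 1 with compound 2 and compound 3 shows only that other parts of the shared core can move the number over a wide span. Compound 4 is therefore expected to give a number of similar order, estimated at 400 nM with a range of 120 nM to 1500 nM. That estimate means a step of a 1.8-fold lower number from compound 1 to compound 4 (0.24 log units; within the scatter), which is expected to stay close to the scatter.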

Compound 4, half-maximal inhibitory concentration: 1100 nM
Compound 4: the middle estimate sits 2.8-fold (0.44 log units) below what was measured; the range from low to high includes it.
By their numbers in this assay, from the lowest: compound 3; then compound 2; then compounds 1 and 4 (each within the scatter of the next).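

At this position, on a nitrogen on an aromatic ring, this assay barely registers the exchange of (3-hydroxycyclobutyl)methyl for 3-carbamoyl-2,2-dimethylcyclobutyl: the step is a 1.6-fold higher number from compound 1 to compound 4 (0.20 log units; within the scatter) and does not separate the two compounds. The substituent can therefore go from 6 heavy atoms to 9, and the hydroxyl can give way to a carbamoyl group on a four-membered carbon ring, with the count of one hydrogen-bond donor and one hydrogen-bond acceptor unchanged and no shift in the number beyond the scatter. Nothing available gives a reason for this outcome.

Because the two methyl groups, the carbamoyl group and the altered link to the nitrogen all enter together, the compounds shown cannot assign any part of the step to any one of these features, and the near-cancellation of opposing contributions cannot be excluded. On these data alone, it also remains open how this position would respond to a carboxylic acid or an amine in place of the carbamoyl group on the 2,2-dimethylcyclobutyl ring, or to the same ring without its two methyl groups.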